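The compounds below may be only part of what the source reports. "The series", "measured", "known", "first", "only" and "open" are said of these compounds alone.

Measured so far:
compound 1 `O=C(NCCCCc1ccccc1)n1c(=O)oc2cc(C3CCOCC3)ccc21` – 68 nM
compound 2 `CN1CCC(c2ccc3c(c2)oc(=O)n3C(=O)NCCCCc2ccc(F)cc2)CC1` – 94 nM
compound 3 `O=C(NCCCCc1ccccc1)n1c(=O)oc2ccncc21` – 6 nM

In an assay on HEK293 cells for inhibition of acid ceramidase (Homo sapiens), read by fluorescence, with stated times of 10 min and 3 h (a higher number here means a weaker inhibitor, a lower number a stronger inhibitor), compound 1 gives 68 nM, the second highest of the three numbers. Its nearest neighbour is compound 2 at 94 nM, which lies within the scatter of compound 1, so the two show no ordering. Compound 3 gives 6 nM, the lowest number of the set and beyond the scatter from compound 1.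

The step under consideration leads from compound 1 to compound 4 `CCN1CCN(c2ccc3c(c2)oc(=O)n3C(=O)NCCCCc2ccccc2)CC1`, not yet measured in this assay. The change is 4-ethylpiperazin-1-yl in place of oxan-4-yl on an aromatic carbon. Within the data shown here, no measured pair differs in this one place, so the size of the step is not known from data. Compound 2 also carries a six-membered non-aromatic ring with a nitrogen at this position of the shared core, and its value sits within the scatter of compound 1, though compound 2 differs elsewhere as well.

The step from compound 1 to compound 4 is expected to be small, a 1.3-fold higher number from compound 1 to compound 4 (0.12 log units; within the scatter), toward a somewhat higher number but not clearly beyond the scatter. Compound 4 is estimated at 90 nM, with a range of 30 nM to 270 nM, since compound 2 gives 94 nM and compound 1 gives 68 nM.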

Compound 4, half-maximal inhibitory concentration: 56 nM
The estimate for compound 4 lay 1.6-fold (0.21 log units) above the measured number; the range from low to high includes it.
By their numbers in this assay, from the lowest: compound 3; then compounds 4, 1 and 2 (each within the scatter of the next).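

In this assay, among these compounds, the only pair that differs solely at this position gives a 1.2-fold lower number from compound 1 to compound 4 (0.08 log units; within the scatter) with 4-ethylpiperazin-1-yl in place of oxan-4-yl on the aromatic carbon. Among the compounds shown here, this is the first direct reading at this place: a six-membered non-aromatic ring with 2 hetero atoms and one with 1 hetero atom are not separated here, even though the entering group has an ethyl on its ring and nitrogen where the leaving group has oxygen. Nothing available bears on why these two groups read alike.

From the compounds shown here alone, whether the same holds at this aromatic carbon for a carboxylic acid, an open-chain amine or a longer alkyl chain remains open, as does whether a piperazin-1-yl without the ethyl reads like compound 4. Also open is what the substituent contributes at all, since the core of compound 1 with only hydrogen on that carbon does not appear among these compounds, and one such pair would show whether either ring matters to the read-out.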